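Adding a methoxy to compound 2

The source may report more compounds than this note shows. Statements on the series, on what has been measured and on what is new or still open speak of the compounds shown alone.

Results so far in a functional assay on K562 cells (Homo sapiens) for inhibition, with a stated time of 72 h (on this read-out lower numbers stand for stronger inhibition and higher numbers for weaker inhibition), are:
Compound 1 `NC1CCC(Nc2nc(NCc3ccc(Br)cc3)c3ncn(C4CCCC4)c3n2)CC1` gives 1170 nM here
Compound 2 `NC1CCC(Nc2nc(NCc3ccc(-c4ccccc4)cc3)c3ncn(C4CCCC4)c3n2)CC1` gives 530 nM here

For the measured compounds named here, compound 2 holds the lower of these two numbers in this assay and compound 1 is its only neighbour. Going by the values given here, compound 3 `COc1ccccc1-c1ccc(CNc2nc(NC3CCC(N)CC3)nc3c2ncn3C2CCCC2)cc1` differs from compound 2 by methoxy in place of hydrogen on an aromatic carbon as its single change, with methoxy in place of hydrogen on an aromatic carbon, ortho to a large group. Among the compounds with values here, one measured step bears on this, the modest 2.2-fold lower number from compound 1 to compound 2 (0.34 log units; beyond the scatter) seen with phenyl in place of bromo. Within the data shown here, no measured compound carries a group on that phenyl, so this step offers only a rough scale. Little change is therefore expected, in neither direction beyond the scatter. The expected step is a 1.2-fold lower number from compound 2 to compound 3 (0.07 log units; within the scatter) on this estimate. Compound 3 is estimated at 450 nM in this assay with an expected range from 150 nM to 1300 nM overall.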

Compound 3, half-maximal inhibitory concentration: 347 nM
For compound 3 the middle estimate is 1.3-fold (0.11 log units) above the measured one; the range from low to high includes it.
By their numbers in this assay, from the lowest: compounds 3 and 2 (each within the scatter of the next); then compound 1.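

In this assay, methoxy in place of hydrogen on the outer phenyl, ortho to a large group, gives a 1.5-fold lower number from compound 2 to compound 3 (0.18 log units; within the scatter) and so leaves compound 2 and compound 3 indistinguishable, which shows that this position accepts a methoxy with no change beyond the scatter. Measured against bromo, the 2-methoxyphenyl group gives a 3.4-fold lower number from compound 1 to compound 3 (0.53 log units; beyond the scatter) and, like the plain phenyl with a 2.2-fold lower number from compound 1 to compound 2 (0.34 log units; beyond the scatter) as its step, stands clear of the scatter. Nothing available explains these numbers.

The compounds shown leave open whether a different group at this position, such as an amine, a carboxylic acid or a fluorine, would be accepted in the same way. They also leave open whether a methoxy elsewhere on that phenyl would give a similar number.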